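The source may hold more compounds than are shown below. What is called first, only, known or untested is meant among the compounds shown, and "the series" means these compounds.

Compound 1 `COCOc1cc(OC)cc(OC)c1C(=O)/C=C/c1ccccc1`: > 20000 nM
Compound 2 `COCOc1cc(OCOC)c(C(=O)/C=C/c2ccccc2)c(OCOC)c1`: > 20000 nM

In a functional assay on HCT-116 cells (Homo sapiens) for cytotoxicity, read by resazurin assay, with a stated time of 72 h (on this read-out higher numbers stand for weaker inhibition and lower numbers for stronger inhibition), compound 2 gives > 20000 nM, which is a limit and not a number. The record so far is the limit of > 20000 nM in this assay, at which 2 of the 2 values shown sit.

Compound 3 `COCOc1cc(OC)c(C(=O)/C=C/c2ccccc2)c(OCOC)c1` differs from compound 2 by hydrogen in place of methoxy on a saturated chain carbon bound to an oxygen on an aromatic ring, so one methoxymethoxy becomes methoxy.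

Compound 1, which also carries both methoxy and methoxymethoxy, shows the limit > 20000 nM. No step beyond the scatter is therefore expected in this assay, in either direction.

The estimated change is a step that the limit leaves unreadable from compound 2 to compound 3.

Compound 3 is expected near 25000 nM, within an estimated range of 12000 nM to 50000 nM, and will most likely be reported as a limit again.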

Compound 3, half-maximal inhibitory concentration: > 20000 nM
Compound 3 ended at the assay's limit; the forecaster's own chance of this, stated with the estimate: 85%; the middle value is on the limit's open side.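

In this assay compound 3 gives > 20000 nM, which is a limit and not a number. No step among compound 1, compound 2 and compound 3 can be read: the limit of > 20000 nM in this assay, at which 3 of the 3 values shown sit.

The compounds shown leave open whether methoxymethoxy or methoxy makes any difference to cytotoxicity in these cells.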